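This account rests on a few compounds, and the source may have more. Where it says the series, first, only, none or still open, it means among the compounds named here.

Measured in a functional assay on NCI-H460 cells (Homo sapiens) for inhibition, read by sulforhodamine B assay, with a stated time of 48 h; a lower number here means a stronger inhibitor of growth, a higher number a weaker inhibitor of growth:

Compound 1 `Cc1ccc(C2=NN(c3ccc(S(C)(=O)=O)cc3)C(=O)CC2)cc1`: > 100000 nM
Compound 2 `Cc1cc(O)ccc1C1=NN(c2ccc(S(C)(=O)=O)cc2)C(=O)CC1`: > 100000 nM

Each of these entries is a limit of the assay and not a number.

Compound 2 therefore has no exact place on the scale. Its result is the limit > 100000 nM, and the only other result shown is a limit too. Going by the values given here, the one measured step is a step that the two limits leave unreadable from compound 1 to compound 2, in which 4-hydroxy-2-methylphenyl stands in place of 4-methylphenyl on a carbon with a double bond to nitrogen.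

The next compound is compound 3 `CCc1ccc(C2=NN(c3ccc(S(C)(=O)=O)cc3)C(=O)CC2)cc1`. The change is 4-ethylphenyl in place of 4-hydroxy-2-methylphenyl on a carbon with a double bond to nitrogen. In words, 4-ethylphenyl replaces 4-hydroxy-2-methylphenyl at that same carbon, and the rest of the molecule stays as it is.

Among the compounds with values here, the only evidence that bears on this change is a step that the two limits leave unreadable from compound 1 to compound 2, together with the limit of > 100000 nM in this assay, at which 2 of the 2 values shown sit. Neither gives a step of readable size, so no step beyond the scatter is expected in this assay, in either direction. A report of only a limit is the likely outcome.

The estimated step is a number no higher from compound 2 to compound 3 (the limit leaves the size open).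

Compound 3 is expected at about 100000 nM, with an estimated range of 50000 nM to 200000 nM.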

Compound 3, concentration for total growth inhibition: 36900 nM
Estimate against measurement, compound 3: 2.7-fold (0.43 log units) above; measured number below the stated range.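

In this assay, compound 3, carrying 4-ethylphenyl on the carbon with a double bond to nitrogen, gives 36900 nM. Going by these compounds alone, the carbon with a double bond to nitrogen now shows for the first time that a change at this place can move the result from a limit to a number. Putting 4-ethylphenyl in place of 4-hydroxy-2-methylphenyl gives an at least 2.7-fold lower number from compound 2 to compound 3 (0.43 log units; beyond the scatter), and the smaller change of a methyl in place of hydrogen on a saturated chain carbon bound to an aromatic carbon gives an at least 2.7-fold lower number from compound 1 to compound 3 (0.43 log units; beyond the scatter), so even this small extension of the 4-methylphenyl group is enough to produce a step beyond the scatter. Both steps start from a limit of the assay and not from a number, which leaves their full size unknown: the limit of > 100000 nM in this assay, at which 2 of the 3 values shown sit.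

Within the data shown here, with compound 3 as the only compound here that has a number, these results cannot show a trend with chain length, and a longer chain such as propyl or butyl on the phenyl ring could lower the number further or lose the gain. As far as these compounds go, it also remains open how an amine or a carboxylic acid would behave on the phenyl ring in place of the ethyl group.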